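A few compounds are considered here, and "the series" means these few. Any claim that something is new, unique, unknown or untested is made for them only; others in the source may bear on it.

Four close relatives share one core, a chain carrying an ester at its far end, and differ only in the length of that chain. Compound 1 is `CCCCCCCOC(=O)CCC(=O)N1CCN(CCCOc2cc3c(Nc4ccc(F)c(Cl)c4)ncnc3cc2OC)CC1`, compound 2 is `CCCCCCCCCOC(=O)CCC(=O)N1CCN(CCCOc2cc3c(Nc4ccc(F)c(Cl)c4)ncnc3cc2OC)CC1`, compound 3 is `CCCCCCCCCCCCOC(=O)CCC(=O)N1CCN(CCCOc2cc3c(Nc4ccc(F)c(Cl)c4)ncnc3cc2OC)CC1`, and the still unmeasured compound 4 is `CCCCCCCCCCCCCCCCOC(=O)CCC(=O)N1CCN(CCCOc2cc3c(Nc4ccc(F)c(Cl)c4)ncnc3cc2OC)CC1`.

In a functional assay on A549 cells (Homo sapiens) for cytotoxicity, read by MTT assay, with a stated time of 24 h, tested at 10 uM (a lower number here means a stronger effect, a higher number a weaker effect of the compound at the concentration tested), compound 1 gives 89.1%, compound 2 gives 90%, and compound 3 gives 95.5%. Compound 3 shows the highest of the three numbers as reported, yet its gap to compound 2, a number 5.5 percentage points higher from compound 2 to compound 3 (within the scatter), and its gap to compound 1, a number 6.4 percentage points higher from compound 1 to compound 3 (within the scatter), are both within the scatter, so no real ordering can be read from them. The shortest step, a number 0.9 percentage points higher from compound 1 to compound 2 (within the scatter), says the same.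

The move to compound 4 is butyl in place of hydrogen on a saturated chain carbon, ten or more bonds along the chain from an oxygen next to a carbonyl group. Every earlier lengthening of this same chain, whether by ethyl, propyl or pentyl, left this assay unchanged beyond the scatter, so a further butyl is expected to do the same: the step of a number 0.5 percentage points lower from compound 3 to compound 4 (within the scatter) is expected to stay within the scatter. Compound 4 is therefore estimated at 95% in this assay, with a plausible range from 85% to 100%.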

Compound 4, a percentage reported as activity, at one concentration (the size of the read-out at that concentration, not a potency): 97.7%
Compound 4: the middle estimate sits 2.7 percentage points below what was measured; measured number inside the range.
By their numbers in this assay, from the lowest: compounds 1, 2, 3 and 4 (each within the scatter of the next).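

In this assay, butyl in place of hydrogen on a saturated chain carbon, ten or more bonds along the chain from an oxygen next to a carbonyl group, brings no readable change (a number 2.2 percentage points higher from compound 3 to compound 4 (within the scatter)), so the chain can grow by this further piece with no effect that stands out from the scatter. What the new compound adds is a much longer reach, since even the largest additions now available, heptyl (a number 7.7 percentage points higher from compound 2 to compound 4 (within the scatter)) and nonyl (a number 8.6 percentage points higher from compound 1 to compound 4 (within the scatter)), stay within the scatter, and so the flat picture now holds across the widest span of chain lengths shown. Nothing measured alongside these numbers bears on why the read-out stays level across these chains.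

The compounds shown all carry the same ester, so the effect of a carboxylic acid or an amine in its place in this assay remains open. A much shorter chain, such as methyl or ethyl on that ester, also remains open, as does the behaviour of any of these compounds at a higher concentration.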